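From Anilino to Allylamino in a Weak Cytotoxic Series

A few compounds are considered here, and "the series" means these few. Any claim that something is new, unique, unknown or untested is made for them only; others in the source may bear on it.

Of the compounds shown here, two have so far been tested in a functional assay on PANC-1 cells (Homo sapiens) for cytotoxicity, read by resazurin assay, with a stated time of 48 h; a lower number here means a stronger inhibitor, a higher number a weaker inhibitor. Compound 1 `CCOc1ccc(NC(=O)c2c(N)n[nH]c2Nc2ccccc2)cc1` gives 21000 nM in this assay, the higher of the two numbers recorded. Compound 2 `CCOc1ccc(-n2nnc3n[nH]c(Nc4ccccc4)c3c2=O)cc1` gives 13100 nM in this assay; the gap between compound 1 and compound 2 lies within the usual scatter of repeated measurements, so the two cannot be set apart. Among the measured compounds shown here, no step between measured compounds that differ in a single place is available.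

Compound 3 `C=CCNc1[nH]nc(N)c1C(=O)Nc1ccc(OCC)cc1` has not yet been measured. It differs from compound 1 in one place: allyl in place of phenyl on a nitrogen on an aromatic ring. For the measured compounds named here, no measured pair shows what this change does, so the expectation rests on compound 1 alone, whose weak value of 21000 nM sets the starting point. The step is expected to be small, a 1.2-fold higher number from compound 1 to compound 3 (0.08 log units; within the scatter), most likely no further than the scatter and in no confident direction. For compound 3 the estimate in this assay is 25000 nM, with a range from 9000 nM to 70000 nM.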

Compound 3, half-maximal inhibitory concentration: 30800 nM
The estimate for compound 3 lay 1.2-fold (0.09 log units) below the measured number, within the range that was stated.
By their numbers in this assay, from the lowest: compounds 2, 1 and 3 (each within the scatter of the next, the first and the last beyond it).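

In this assay, among the compounds shown here, replacing phenyl with allyl on a nitrogen on an aromatic ring gives the first step that can be read at this position, a 1.5-fold higher number from compound 1 to compound 3 (0.17 log units; within the scatter), and this pair cannot be set apart. The result therefore shows that anilino can give way to allylamino, with the six-membered aromatic ring of carbon only removed and 3 heavy atoms entering where 6 leave, without a difference that this assay can resolve, and the aromatic ring on that nitrogen is not shown to be needed for the weak activity of compound 1. Nothing measured here bears on this result.

A single pair cannot say whether other groups on this nitrogen, such as a substituted phenyl, a saturated propyl chain, or a longer chain ending in an amine or a carboxylic acid, would move the number beyond the scatter. On these data alone, whether the change from anilino to allylamino would read the same way on the core of compound 2 also remains open.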